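The source may report more compounds than this note shows. Statements on the series, on what has been measured and on what is new or still open speak of the compounds shown alone.

Measured compounds:

Compound 1 `CC(=O)OCCn1cc(C(=O)NCc2cn(Cc3ccccc3)nn2)nn1`; in a functional assay on B16 cells (Mus musculus) for cytotoxicity, read by MTT assay, with a stated time of 48 h (a higher number here means a weaker inhibitor, a lower number a stronger inhibitor), compound 1 gives > 100000 nM, which is a limit of the assay and not a number.
Compound 2 `CCOC(=O)Cn1cc(CNC(=O)c2cn(CCOC(C)=O)nn2)nn1`; in this assay compound 2 gives > 100000 nM, again a limit of the assay.
For the measured compounds named here, compound 3 `O=C(Nc1cccc(-c2cn(Cc3ccccc3)nn2)c1)c1cn(Cc2ccccc2)nn1`; in this assay compound 3 gives 4500 nM, the only number among the three.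

The change from compound 1 to compound 2 is ethoxycarbonyl in place of phenyl on a saturated chain carbon bound to an aromatic nitrogen. Its step, a step that the two limits leave unreadable from compound 1 to compound 2, cannot be read because of the limit of > 100000 nM in this assay, at which 2 of the 3 values shown sit. The core of compound 3 differs from the core of compound 1, but that difference is not broken down here.

Compound 4 `CCOC(=O)Cn1cc(-c2cccc(NC(=O)c3cn(Cc4ccccc4)nn3)c2)nn1` is not yet measured. It differs from compound 3 by ethoxycarbonyl in place of phenyl on a saturated chain carbon bound to an aromatic nitrogen, the same change as from compound 1 to compound 2, at the same place. Since the earlier step gives no readable size, the expectation for compound 4 rests on compound 3 and its value 4500 nM alone, with a wide range. The step of a 1.6-fold higher number from compound 3 to compound 4 (0.19 log units; within the scatter) is the estimate adopted here. Compound 4 is accordingly expected to give about 7000 nM in this assay, between 1500 nM and 40000 nM.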

Compound 4, half-maximal inhibitory concentration: 21000 nM
Estimate against measurement, compound 4: 3.0-fold (0.48 log units) below, and the stated range covers the measured number.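

On the core of compound 3, ethoxycarbonyl in place of phenyl on a saturated chain carbon bound to an aromatic nitrogen gives, in this assay, a 4.7-fold higher number from compound 3 to compound 4 (0.67 log units; beyond the scatter), a modest step and the only readable size for this change. The same change on the core of compound 1 cannot be read, so the size of the step cannot be compared between the two cores: the limit of > 100000 nM in this assay, at which 2 of the 4 values shown sit. The change is therefore measured on one core only, and the series shows neither that its size carries over to another core nor that it does not.

Going by these compounds, it remains open whether a carboxylic acid or an amine in place of ethoxycarbonyl, at the same place, would stay near compound 4 at 21000 nM or move further from compound 3 at 4500 nM. Also open is how the remaining benzyl of compound 4 contributes, since no pair shown changes that group alone.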